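A few compounds are considered here, and "the series" means these few. Any claim that something is new, unique, unknown or untested is made for them only; others in the source may bear on it.

Compound 2 `O=C(Nc1ccncc1)Nc1ccccc1C(F)(F)F` stands in a functional assay on the whole organism with Mus musculus as the target, in the maximal electroshock model, with a stated time of 30 min (a higher number here means that more compound is needed for the effect, a lower number that less compound is needed), at 100 mg/kg, level with compound 1 `O=C(Nc1ccncc1)Nc1ccccc1F`, which in this assay gives 100 mg/kg. Among the measured compounds shown here, the one measured step, no change at the digits printed from compound 1 to compound 2 (within the scatter), came with trifluoromethyl in place of fluoro on an aromatic carbon, so the series so far holds two compounds at the same value and no step beyond the scatter.

Compound 3 `CN(C)c1ccccc1NC(=O)Nc1ccncc1` differs from compound 2 by dimethylamino in place of trifluoromethyl on an aromatic carbon. The step from compound 1 to compound 2 bears on it only in that it exchanged one group at the same aromatic carbon without moving the number; nothing measured speaks for a step in this assay in either direction, and the working expectation is a step of no change at the digits printed from compound 2 to compound 3 (within the scatter) that stays within the scatter. For compound 3 the estimate in this assay is 100 mg/kg, with a range from 30 mg/kg to 300 mg/kg.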

Compound 3, minimum effective dose: 100 mg/kg
The estimate for compound 3 equals the measured number at the digits printed; the measured number falls inside the stated range.
By their numbers in this assay, from the lowest: compounds 1, 2 and 3 (each within the scatter of the next).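

The exchange of trifluoromethyl for dimethylamino gives no change at the digits printed from compound 2 to compound 3 (within the scatter) in this assay and the exchange of fluoro for dimethylamino gives no change at the digits printed from compound 1 to compound 3 (within the scatter) at the same aromatic carbon. This adds to the series a group with a nitrogen and a hydrogen-bond acceptor, and the read-out still does not separate the three groups at this carbon. No measurement shown here offers an explanation for this result.

As far as these compounds go, whether a carboxylic acid, a primary amine or a longer alkyl chain on this aromatic carbon would give a step beyond the scatter remains open. Also open, from the compounds shown here alone, is whether the same exchanges on another aromatic carbon of the shared core would leave the number in place.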